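The compounds below may be only part of what the source reports. "The series", "measured", "known", "first", "only" and "open" are said of these compounds alone.

Compound 3, with the structure `Fc1ccc(-c2nc3sc(Cc4ccc(Cl)cc4)nn3c2Br)cc1`, was tested in an ADME assay on CCRF-CEM cells (Homo sapiens) for cytotoxicity, with a stated time of 72 h; on this read-out lower numbers stand for stronger inhibition and higher numbers for weaker inhibition. In this assay compound 3 gives > 250000 nM, which is a limit of the assay and not a number. Two close relatives were measured the same way. Compound 1, `Fc1ccc(-c2cn3nc(Cc4ccc(Cl)cc4)sc3n2)cc1`, gives > 250000 nM in this assay, again a limit. Compound 2, `Clc1ccc(Cc2nn3cc(-c4ccccc4)nc3s2)cc1`, gives > 250000 nM in this assay, also a limit. The whole picture is summed up by the limit of > 250000 nM in this assay, at which 3 of the 3 values shown sit, so compound 3 cannot be placed higher or lower than its neighbours on these numbers.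

Compound 4, `Clc1ccc(Cc2nn3c(Br)c(-c4ccc(Cl)cc4)nc3s2)cc1`, has not yet been measured. The change from compound 3 is chloro in place of fluoro on an aromatic carbon. Of the measured steps, a step that the two limits leave unreadable from compound 1 to compound 2 and a step that the two limits leave unreadable from compound 1 to compound 3 come closest, but neither has a readable size, since both compounds in each pair sit at the limit. For the measured compounds named here, they give no direction for the step to compound 4; they show only that changes at the ring edges of the shared core left every value at the limit. The step of a number no higher from compound 3 to compound 4 (the limit leaves the size open) is therefore expected to be small or none beyond the scatter. Compound 4 is estimated at 250000 nM in this assay, with a range from 100000 nM to 600000 nM, and the assay will most likely again report only a limit.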

Compound 4, half-maximal inhibitory concentration: > 250000 nM
Compound 4: only a limit was reported; the forecaster's own chance of this, stated with the estimate: 85%; the middle value lies on the limit itself.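

Compound 3 and compound 4 both reach only a limit of the read-out in this assay, so no size can be read for the change from 4-fluorophenyl to 4-chlorophenyl. The compounds shown leave open which change to the shared core, if any, would give a true measured number, because every result so far is the same limit: the limit of > 250000 nM in this assay, at which 4 of the 4 values shown sit.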